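Arylethyl for biaryl at the pyridine position of compound 2

A few compounds are considered here, and "the series" means these few. Any claim that something is new, unique, unknown or untested is made for them only; others in the source may bear on it.

Measured so far:
Compound 1, `CC(C(=O)NCc1ccc(C(F)(F)F)nc1-c1ccc(C(C)(C)C)cc1)c1ccc(NS(C)(=O)=O)c(F)c1`: 0.5 nM
Compound 2, `COc1ccc(-c2nc(C(F)(F)F)ccc2CNC(=O)C(C)c2ccc(NS(C)(=O)=O)c(F)c2)cc1F`: 4.2 nM
Compound 3, `COc1ccc(-c2nc(C(F)(F)F)ccc2CNC(=O)C(C)c2ccc(NS(C)(=O)=O)c(F)c2)cc1OC`: 25.6 nM

In an assay on CHO cells for antagonist activity at transient receptor potential cation channel subfamily V member 1 (Homo sapiens), read by FLIPR (on this read-out higher numbers stand for weaker inhibition and lower numbers for stronger inhibition), compound 2 gives 4.2 nM, the second highest of the three numbers; compound 1 sits an 8.4-fold higher number from compound 1 to compound 2 (0.92 log units; beyond the scatter) away and compound 3 a 6.1-fold higher number from compound 2 to compound 3 (0.78 log units; beyond the scatter) away. Compound 4, `Cc1ccc(CCc2nc(C(F)(F)F)ccc2CNC(=O)C(C)c2ccc(NS(C)(=O)=O)c(F)c2)cc1`, differs from compound 2 by 2-(4-methylphenyl)ethyl in place of 3-fluoro-4-methoxyphenyl on an aromatic carbon. Among the compounds with values here, no measured step replaces an aryl group at this aromatic carbon with a two-carbon chain bearing an aryl group, so the bearing steps are only indirect: an 8.4-fold higher number from compound 1 to compound 2 (0.92 log units; beyond the scatter) and a 6.1-fold higher number from compound 2 to compound 3 (0.78 log units; beyond the scatter) show that changes at this position move this assay by modest amounts. Compound 4 is therefore expected to shift by a 4.8-fold higher number from compound 2 to compound 4 (0.68 log units; beyond the scatter) toward a higher number, with wide uncertainty. The estimate for compound 4 is 20 nM, within 3 nM to 150 nM.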

Compound 4, inhibition constant: 0.6 nM
Beside the measured number, compound 4's estimate is 33-fold (1.52 log units) above it; measured number outside the range, below it.
By their numbers in this assay, from the lowest: compounds 1 and 4 (each within the scatter of the next); then compound 2; then compound 3.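

In this assay, the 2-(4-methylphenyl)ethyl group shows that an aryl group need not sit directly on this aromatic carbon: the change gives a 7.0-fold lower number from compound 2 to compound 4 (0.85 log units; beyond the scatter) and a 43-fold lower number from compound 3 to compound 4 (1.63 log units; beyond the scatter) (both beyond the scatter). It also gives a 1.2-fold higher number from compound 1 to compound 4 (0.08 log units; within the scatter) (within the scatter), so this chain matches the 4-(tert-butyl)phenyl group. No supporting evidence bears on why this chain behaves this way. As far as these compounds go, whether a longer chain or a one-carbon chain would keep this result remains open. So does the effect of an amine in the chain.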